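Replacing the nitrogen substituent of compound 1 with sec-butyl

The compounds below may be only part of what the source reports. "The series", "measured", "known", "first", "only" and "open" are said of these compounds alone.

- compound 1 `COc1ccc(NC(=O)C(=O)c2cn(C(C)(C)COCC(=O)O)c3ccccc23)cn1` (> 10000 nM, a limit and not a number)
- compound 2 `CCOc1ccc(NC(=O)C(=O)c2cn(C(C)C)c3ccccc23)cn1` (175 nM)
- compound 3 `COc1ccc(NC(=O)C(=O)c2cn(C(C)C)c3cccc(OC)c23)cn1` (7780 nM)

All three results come from a functional assay on FaDu cells (Homo sapiens) for cytotoxicity, read by MTT assay, with a stated time of 72 h; on this read-out lower numbers stand for higher toxicity in this test and higher numbers for lower toxicity in this test. Compound 1 has no numerical value and stands only at a limit, (the limit of > 10000 nM in this assay, at which 1 of the 3 values shown sits). The next compound to be read is compound 4 `CCC(C)n1cc(C(=O)C(=O)Nc2ccc(OC)nc2)c2ccccc21`, which keeps the core of compound 1 and changes one group on an aromatic nitrogen: a group of 4 heavy atoms (4 carbon; no ring) in place of a group of 9 heavy atoms (6 carbon, 3 oxygen; no ring), on an aromatic nitrogen. Sec-butyl thus takes the place of a group with no common name that carries the only hydrogen-bond donor counted in the change.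

Among the measured compounds shown here, no step between measured compounds gives the size of this change directly. The nearest guidance is that two compounds without the departing group give numbers: compound 2 gives 175 nM and compound 3 gives 7780 nM. These two values lie far apart, so the expectation remains wide. The step of an at least 28-fold lower number from compound 1 to compound 4 (1.45 log units; beyond the scatter) is expected to be large and towards higher toxicity in this assay, although its true size is uncertain while compound 1 has only a limit. For compound 4 the expected value is 350 nM. The estimated range for compound 4 runs from 60 nM to 3000 nM.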

Compound 4, concentration lethal to 50% of the cells: 68 nM
For compound 4 the middle estimate is 5.1-fold (0.71 log units) above the measured one; measured number inside the range.
By their numbers in this assay, from the lowest: compound 4; then compound 2; then compound 3. At a limit, above all of these: compound 1.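

In this assay, the substituent on the aromatic nitrogen is a sensitive place on this core: with everything else held constant, sec-butyl in place of the group with no common name gives an at least 140-fold lower number from compound 1 to compound 4 (2.16 log units; beyond the scatter). Among the compounds shown here, the swap changes several things at once, since the departing chain has a ring-free ether and acid end, holds the hydrogen-bond donor and acceptors counted in this change and is larger, whereas sec-butyl is a plain carbon group with none of these, and the single step cannot separate those features. Compound 1 stands at a limit and not at a number, and the step therefore gives only a lower bound on the size of the change: the limit of > 10000 nM in this assay, at which 1 of the 4 values shown sits.

The compounds shown leave open which part of the departing group accounts for the step: the carboxylic acid, the ether oxygen, the chain length or the branching next to the nitrogen is not resolved. A methyl ester of the same chain, a primary amine at its end, or a straight n-butyl or a cyclopentyl group at this nitrogen would each test one of these separately.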